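This account rests on a few compounds, and the source may have more. Where it says the series, first, only, none or still open, it means among the compounds named here.

Two compounds share the same core and have been run through a functional assay on HT-29 cells (Homo sapiens) for inhibition, read by sulforhodamine B assay, with a stated time of 48 h; a higher number here means a weaker inhibitor of growth, a lower number a stronger inhibitor of growth. Compound 1 `COc1cc(-c2nn(-c3cccc(NC(=O)Nc4ccc(Cl)c(Cl)c4)c3)cc2-c2ccncc2)ccc1Cl` gives 1240 nM in this assay, and compound 2 `COc1cc(-c2nn(-c3cccc(NC(=O)Nc4ccc(Cl)c(C(F)(F)F)c4)c3)cc2-c2ccncc2)ccc1Cl` gives 1190 nM. Compound 2 has the lowest of the two numbers, but its nearest neighbour, compound 1, sits only a 1.0-fold lower number from compound 1 to compound 2 (0.02 log units; within the scatter) away, so the two cannot be told apart on these measurements.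

Compound 3 `COc1cc(-c2nn(-c3cccc(NC(=O)c4ccccc4)c3)cc2-c2ccncc2)ccc1Cl` has not yet been measured in this assay. It differs from compound 2 by phenyl in place of (4-chloro-3-(trifluoromethyl)phenyl)amino on a carbonyl carbon. For the measured compounds named here, the single measured step, from compound 1 to compound 2, altered a substituent on the distal aromatic ring and left the carbonyl and both attached nitrogens untouched; the change from compound 2 to compound 3 removes one of those nitrogens together with the whole distal ring, so that step offers no guide to its size or direction. Going by the values given here, with no comparable step among the measured compounds, the expectation rests on the scale of the change alone. Compound 3 is expected to give a higher number than compound 2, a step of a 5.0-fold higher number from compound 2 to compound 3 (0.70 log units; beyond the scatter), so the estimate for compound 3 in this assay is 6000 nM, within a range from 1500 nM to 30000 nM.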

Compound 3, concentration for 50% growth inhibition: 392 nM
Estimate against measurement, compound 3: 15-fold (1.18 log units) above, outside the stated range (below it).
By their numbers in this assay, from the lowest: compound 3; then compounds 2 and 1 (each within the scatter of the next).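

In this assay, phenyl in place of (4-chloro-3-(trifluoromethyl)phenyl)amino on a carbonyl carbon brings a 3.0-fold lower number from compound 2 to compound 3 (0.48 log units; beyond the scatter), and phenyl in place of (3,4-dichlorophenyl)amino at the same place brings a 3.2-fold lower number from compound 1 to compound 3 (0.50 log units; beyond the scatter). The earlier pair showed only that exchanging chloro for trifluoromethyl on the outer ring left the number unmoved, whereas these steps show that this position does respond to change, and that the larger substituted amino groups, with their hydrogen-bond donor, are not required for growth inhibition, since compound 3 has the lowest number of the three. The data offer no measured property that would explain this shift.

The steps change two things at once, the amino nitrogen and the substituents on the ring, so the compounds shown cannot say which of them accounts for the lower number. A plain phenylamino group on the carbonyl carbon would address one side of this and a 4-chloro-3-(trifluoromethyl)phenyl group attached directly to that carbon the other, while a saturated ring such as morpholine or a short alkyl chain there would test whether an aromatic ring is needed at all.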